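Removing One Methyl from Compound 1: Unbound Fraction Outlook

The compounds below may be only part of what the source reports. "The series", "measured", "known", "first", "only" and "open" are said of these compounds alone.

Measured compounds:
Compound 1, `Cc1cn([C@H]2CCCN([C@@H](CC(C)C)c3ccc(C(=O)O)c(Oc4cccc(Cl)c4)c3F)C2)c(=O)[nH]c1=O` — 0.005
Compound 2, `CC[C@@H](c1ccc(C(=O)O)c(Oc2cccc(Cl)c2)c1OC)N1CCC[C@H](n2cc(C)c(=O)[nH]c2=O)C1` — 0.011

Of the compounds shown here, two have been tested in an ADME assay on a cell-free system (plasma, Mus musculus) for protein binding, using equilibrium dialysis, with a stated time of 5 h, tested at 10 uM; a lower number here means a smaller unbound share, a higher number a larger unbound share of the compound. Compound 1, `Cc1cn([C@H]2CCCN([C@@H](CC(C)C)c3ccc(C(=O)O)c(Oc4cccc(Cl)c4)c3F)C2)c(=O)[nH]c1=O`, gives 0.005; compound 2, `CC[C@@H](c1ccc(C(=O)O)c(Oc2cccc(Cl)c2)c1OC)N1CCC[C@H](n2cc(C)c(=O)[nH]c2=O)C1`, gives 0.011. Compound 1 thus stands at the lower of the two numbers, with compound 2 the nearer and only neighbour, and the gap between them lies beyond the scatter of the assay. Among the compounds with values here, no pair of these two differs in a single place, so no single-change step has been measured.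

The unmeasured compound 3, `CCC[C@@H](c1ccc(C(=O)O)c(Oc2cccc(Cl)c2)c1F)N1CCC[C@H](n2cc(C)c(=O)[nH]c2=O)C1`, differs from compound 1 in one place: hydrogen in place of methyl on a saturated chain carbon bound to two saturated chain carbons. The shared core and the acid are kept. Without a measured step of this kind, the expected size of the step from compound 1 to compound 3 is read as small: a modest increase in the unbound fraction, or none beyond the scatter, is anticipated, with the expected step being a 1.4-fold higher number from compound 1 to compound 3 (0.15 log units; within the scatter). Compound 3 is therefore estimated at 0.007, within a range from 0.003 to 0.016.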

Compound 3, unbound fraction: 0.007
Beside the measured number, compound 3's estimate shows no gap at the digits printed; measured number inside the range.
By their numbers in this assay, from the lowest: compounds 1, 3 and 2 (each within the scatter of the next, the first and the last beyond it).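

In this assay, within the data shown here, hydrogen in place of methyl on a saturated chain carbon bound to two saturated chain carbons gives a 1.4-fold higher number from compound 1 to compound 3 (0.15 log units; within the scatter) as the first step in this set that can be read for a single place. At this position, then, the change from isobutyl to propyl, with the shared core and the acid kept, does not move the unbound fraction beyond the usual scatter, so one methyl at this end of the chain leaves this read-out without a resolved difference. Nothing measured here bears on why the step has this size.

Whether a longer chain, a cyclopropyl ring, a hydroxyl or an amine at this carbon would give a step beyond the scatter stays open, since the compounds shown cover only this one change at the position. Going by these compounds, compound 2 differs from both compound 1 and compound 3 in more than one place, so its number says nothing about this position alone, and how far the chain can be cut before the unbound fraction responds also remains open.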